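One chloro added to compound 2

The source may hold more compounds than are shown below. What is called first, only, known or untested is meant among the compounds shown, and "the series" means these compounds.

In a functional assay on OVCAR-3 cells (Homo sapiens) for inhibition, with a stated time of 48 h (on this read-out higher numbers stand for weaker inhibition of growth and lower numbers for stronger inhibition of growth), compound 1 `COc1c(C(=O)/C=C/c2ccc(Cl)cc2)c(O)c(Br)c2occc12` gives 1910 nM and compound 2 `C=CCc1c(O)c(C(=O)/C=C/c2ccccc2)c(OC)c2ccoc12` gives 2460 nM so that compound 2 stands within the usual scatter of compound 1. Compound 3 `C=CCc1c(O)c(C(=O)/C=C/c2ccc(Cl)cc2)c(OC)c2ccoc12` differs from compound 2 in one place (chloro in place of hydrogen on an aromatic carbon) with chloro in place of hydrogen on an aromatic carbon, turning phenyl to 4-chlorophenyl. Going by the values given here, no measured pair shows this change alone. Compound 1 also bears a 4-chlorophenyl and gives 1910 nM so no step beyond the scatter is expected in this assay in either direction. The estimated step is a 1.2-fold lower number from compound 2 to compound 3 (0.07 log units; within the scatter) and stays within the scatter. For compound 3 the expected value is 2100 nM with 900 nM to 4800 nM as its range.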

Compound 3, concentration for 50% growth inhibition: 1970 nM
For compound 3 the middle estimate is 1.1-fold (0.03 log units) above the measured one; the range from low to high includes it.
By their numbers in this assay, from the lowest: compounds 1, 3 and 2 (each within the scatter of the next).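

In this assay, going by these compounds alone, chloro in place of hydrogen on an aromatic carbon, para to a large group, gives a 1.2-fold lower number from compound 2 to compound 3 (0.10 log units; within the scatter) and so shows no step at this position that stands out from the scatter. Allyl in place of bromo on an aromatic carbon gives a 1.0-fold higher number from compound 1 to compound 3 (0.01 log units; within the scatter) and so leaves these two groups indistinguishable on this read-out when the 4-chlorophenyl is present. No measurement shown here offers an explanation for either result. Still open, going by these compounds, is whether an amine or a carboxylic acid in place of chloro would give a step beyond the scatter. The same question applies to a longer chain in place of allyl.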